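The compounds below may be only part of what the source reports. "The series", "measured", "known", "first", "only" and "open" are said of these compounds alone.

Three compounds share one core, differing only in the aryl group on a double-bonded chain carbon bound to a double-bonded chain carbon. Compound 1 is `COc1ccc(C(=O)/C=C/c2ccc(F)cc2)c2c1C=CC(C)(C)O2`. In a functional assay on SW-620 cells (Homo sapiens) for antiproliferative activity, read by MTT assay, with a stated time of 24 h (on this read-out higher numbers stand for weaker inhibition and lower numbers for stronger inhibition), compound 1 gives > 10000 nM, a limit of the assay rather than a number. Compound 2 is `COc1ccc(C(=O)/C=C/c2cccc(Cl)c2)c2c1C=CC(C)(C)O2`; in this assay compound 2 gives > 10000 nM, also a limit. Compound 3 is `COc1ccc(C(=O)/C=C/c2cccs2)c2c1C=CC(C)(C)O2`; in this assay compound 3 gives > 10000 nM, again a limit. The steps a step that the two limits leave unreadable from compound 1 to compound 3 and a step that the two limits leave unreadable from compound 2 to compound 3 thus bear on compound 3 but cannot be sized, since (the limit of > 10000 nM in this assay, at which 3 of the 3 values shown sit). Compound 4 is `COc1ccc(C(=O)/C=C/c2cc(Cl)ccc2O)c2c1C=CC(C)(C)O2`, differing by 5-chloro-2-hydroxyphenyl in place of thiophen-2-yl on a double-bonded chain carbon bound to a double-bonded chain carbon. Among the compounds with values here, no measured step reads, so the expected step of an at least 1.2-fold lower number from compound 3 to compound 4 (0.09 log units; that floor lies within the scatter) is uncertain. Compound 4 is expected to give 8000 nM, between 1500 nM and 40000 nM.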

Compound 4, half-maximal inhibitory concentration: 4230 nM
Compound 4: middle estimate off by 1.9-fold (0.28 log units), on the high side, and the stated range covers the measured number.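

Compound 4 is the only one of the four to give a number rather than a limit in this assay, so this position can respond to the aryl group. Hydroxy in place of hydrogen on an aromatic carbon gives an at least 2.3-fold lower number from compound 2 to compound 4 (0.37 log units; beyond the scatter) as the one change, while the whole 5-chloro-2-hydroxyphenyl group gives an at least 2.3-fold lower number from compound 3 to compound 4 (0.37 log units; beyond the scatter) and an at least 2.3-fold lower number from compound 1 to compound 4 (0.37 log units; beyond the scatter) as well. The steps among the other three compounds still cannot be read: the limit of > 10000 nM in this assay, at which 3 of the 4 values shown sit.

Going by these compounds, whether the chlorine is needed alongside the hydroxy stays open, as does whether an amine in place of the hydroxy would give a similar number.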